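This account rests on a few compounds, and the source may have more. Where it says the series, first, only, none or still open, it means among the compounds named here.

Three compounds have been measured in a functional assay on MCF7 cells (Homo sapiens) for antiproliferative activity, read by MTT assay, with a stated time of 48 h; on this read-out lower numbers stand for stronger inhibition and higher numbers for weaker inhibition:

Compound 1, `N#CC1=C(N)Oc2c(c3nc4ccccc4nc3c3ccccc23)C12C(=O)N(Cc1cnnn1-c1cc(Cl)ccc1Cl)c1ccccc12`, gives > 50000 nM.
Compound 2, `Cc1ccccc1-n1nncc1CN1C(=O)C2(C(C#N)=C(N)Oc3c(N)cc4nc5ccccc5nc4c32)c2ccccc21`, gives > 50000 nM.
Compound 3, `COc1ccccc1-n1nncc1CN1C(=O)C2(C(C#N)=C(N)Oc3c(N)cc4nc5ccccc5nc4c32)c2ccccc21`, gives 28900 nM.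

For compound 1 the value is a limit of the assay, not a number. For compound 2 the value is likewise a limit. Among the compounds with values here, compound 3 therefore stands as the only compound with a number in this assay, the other two sitting at the limit of > 50000 nM in this assay, at which 2 of the 3 values shown sit. Within the data shown here, the one step measured between compounds that differ in a single place is an at least 1.7-fold lower number from compound 2 to compound 3 (0.23 log units; that floor lies within the scatter), a methoxy in place of a methyl on an aromatic carbon, and its floor lies within the scatter of repeated measurements.

Compound 4, `COc1ccc(OC)c(-n2nncc2CN2C(=O)C3(C(C#N)=C(N)Oc4c(N)cc5nc6ccccc6nc5c43)c3ccccc32)c1`, differs from compound 3 by methoxy in place of hydrogen on an aromatic carbon. Among the measured compounds shown here, the only measured step that bears on this change, the one from compound 2 to compound 3, is small, so no step beyond the scatter is expected. The step from compound 3 to compound 4 is estimated at a 1.2-fold lower number from compound 3 to compound 4 (0.06 log units; within the scatter). For compound 4 the expected value in this assay is 25000 nM, with a range from 9000 nM to 70000 nM.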

Compound 4, half-maximal inhibitory concentration: 28100 nM
For compound 4 the middle estimate is 1.1-fold (0.05 log units) below the measured one; low and high end bracket the measured number.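

In this assay, the methoxy added on the aromatic carbon para to a methoxy group, which turns 2-methoxyphenyl into 2,5-dimethoxyphenyl, leaves the number unchanged within the scatter, with a 1.0-fold lower number from compound 3 to compound 4 (0.01 log units; within the scatter), so this position accepts the added group with no readable change. Compound 2 gives a limit of the assay and not a number: the limit of > 50000 nM in this assay, at which 2 of the 4 values shown sit.

The comparison of 2,5-dimethoxyphenyl with 2-methylphenyl can therefore be read only as a floor, with an at least 1.7-fold lower number from compound 2 to compound 4 (0.25 log units; that floor lies within the scatter).

The compounds shown leave open whether an amine, a hydroxyl or a longer chain such as ethoxy at this same place would move the number beyond the scatter. They also leave open whether a halogen such as fluorine or chlorine there would do so.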